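A few compounds are considered here, and "the series" means these few. Any claim that something is new, unique, unknown or untested is made for them only; others in the source may bear on it.

For the measured compounds named here, in a functional assay on MGC-803 cells (Homo sapiens) for inhibition, read by MTT assay, with a stated time of 48 h (a higher number here means a weaker inhibitor, a lower number a stronger inhibitor), compound 1 `COc1ccc(-c2coc3cc(OCCCSC(=S)N4CCN(C)CC4)ccc3c2=O)cc1` gives 21900 nM and compound 2 `COc1ccc(-c2coc3cc(OCCCSC(=S)N4CCCC4)ccc3c2=O)cc1` gives 40000 nM, so compound 2 stands within the usual scatter of its only measured neighbour. Compound 3 `COc1ccc(-c2coc3cc(OCCCCCBr)ccc3c2=O)cc1` differs from compound 2 in one place: a group of 3 heavy atoms (2 carbon, 1 bromine; no ring) in place of a group of 8 heavy atoms (5 carbon, 1 nitrogen, 2 sulfur; one five-membered non-aromatic ring with 1 hetero atom), on a saturated chain carbon, three bonds along the chain from an oxygen on an aromatic ring. Going by the values given here, the only measured step, a 1.8-fold higher number from compound 1 to compound 2 (0.26 log units; within the scatter), lies within the scatter, but it keeps the thiocarbonyl carbon that this change removes, so it offers only weak guidance. No step beyond the scatter is therefore expected in this assay, in either direction. The expected step is a 1.3-fold lower number from compound 2 to compound 3 (0.12 log units; within the scatter). For compound 3 the estimated value is 30000 nM, with an expected range of 10000 nM to 80000 nM.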

Compound 3, half-maximal inhibitory concentration: > 100000 nM
Compound 3 was reported as a limit; the forecaster's own chance of this, stated with the estimate: 25%; middle value at least 3.3-fold (0.52 log units) away from the limit.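

In this assay, putting 2-bromoethyl on this saturated chain carbon in place of the pyrrolidine-bearing thiocarbonyl group gives an at least 2.5-fold higher number from compound 2 to compound 3 (0.39 log units; beyond the scatter), and the same change from the 4-methylpiperazin-1-yl version gives an at least 4.5-fold higher number from compound 1 to compound 3 (0.65 log units; beyond the scatter). The earlier ring swap on the thiocarbonyl carbon stayed within the scatter, whereas removing the whole group weakens inhibition, so this position is not indifferent to every change. The entry for compound 3 is a limit, not a number: the limit of > 100000 nM in this assay, at which 1 of the 3 values shown sits. From the compounds shown here alone, it remains open which part of the removed group matters, and whether a plain amine such as morpholine, attached directly to the chain without the thiocarbonyl carbon, would keep the inhibition.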